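Swapping a 3-chlorophenyl for a 1H-pyrrol-2-yl group

This account rests on a few compounds, and the source may have more. Where it says the series, first, only, none or still open, it means among the compounds named here.

Measured so far:
Compound 1 `CC1=CC[C@H](C(C)(C)NC(=S)N/N=C/c2ccccc2)CC1`: in a functional assay on NCI/ADR-RES cells (Homo sapiens) for inhibition, read by sulforhodamine B assay, with a stated time of 48 h (on this read-out higher numbers stand for weaker inhibition of growth and lower numbers for stronger inhibition of growth), compound 1 reaches only the assay limit of > 100000 nM.
Compound 2 `COc1ccc(/C=N/NC(=S)NC(C)(C)[C@H]2CC=C(C)CC2)cc1`: compound 2 gives 43800 nM.
Compound 3 `CC1=CC[C@H](C(C)(C)NC(=S)N/N=C/c2cccc(Cl)c2)CC1`: compound 3 gives 67500 nM.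

Among the two real numbers, compound 3 holds the higher one, with compound 2 nearest; the step of a 1.5-fold higher number from compound 2 to compound 3 (0.19 log units; within the scatter) stays within the scatter. For compound 1 there is only a limit (the limit of > 100000 nM in this assay, at which 1 of the 3 values shown sits). Compound 4 `CC1=CC[C@H](C(C)(C)NC(=S)N/N=C/c2ccc[nH]2)CC1` differs from compound 3 by 1H-pyrrol-2-yl in place of 3-chlorophenyl on a carbon with a double bond to nitrogen. The measured steps all touch the same aromatic group: an at least 2.2-fold lower number from compound 1 to compound 2 (0.35 log units; beyond the scatter), an at least 1.4-fold lower number from compound 1 to compound 3 (0.17 log units; that floor lies within the scatter) and a 1.5-fold higher number from compound 2 to compound 3 (0.19 log units; within the scatter), none large. Among the compounds with values here, the only whole-group swap, from compound 2 to compound 3, moved little, so no step beyond the scatter is expected here; the step of a 1.0-fold lower number from compound 3 to compound 4 (0.02 log units; within the scatter) is expected. Compound 4 is therefore estimated at 65000 nM, between 25000 nM and 170000 nM.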

Compound 4, concentration for 50% growth inhibition: 78000 nM
For compound 4 the middle estimate is 1.2-fold (0.08 log units) below the measured one; the measured number falls inside the stated range.
By their numbers in this assay, from the lowest: compounds 2, 3 and 4 (each within the scatter of the next). At a limit, above all of these: compound 1.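

In this assay, the ring at this position can change from a six-membered carbon ring to a five-membered ring with a hetero atom and a hydrogen-bond donor without a step beyond the scatter: a 1.2-fold higher number from compound 3 to compound 4 (0.06 log units; within the scatter), and a 1.8-fold higher number from compound 2 to compound 4 (0.25 log units; within the scatter). Among compounds 2, 3 and 4, then, neither ring size nor the ring's atoms visibly set the number. Against the plain phenyl there is only a floor, an at least 1.2-fold lower number from compound 1 to compound 4 (0.10 log units; that floor lies within the scatter), since compound 1 stands at a limit: the limit of > 100000 nM in this assay, at which 1 of the 4 values shown sits.

On these data alone, whether an amine or a carboxylic acid on this ring would move the number beyond the scatter stays open. So does the effect of a non-aromatic ring here.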